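Replacing acetyl with propargyl on a doubly substituted amine

A few compounds are considered here, and "the series" means these few. Any claim that something is new, unique, unknown or untested is made for them only; others in the source may bear on it.

Compound 1 `C#CCNCc1cn(-c2cc(NC(=S)NCC)ncn2)cn1` carries a secondary amine bearing one propargyl. In an assay on isolated protein for inhibition of Amine oxidase [flavin-containing] A (Homo sapiens), read by fluorescence and Amplex Red, with a stated time of 15 min (on this read-out higher numbers stand for weaker inhibition and lower numbers for stronger inhibition), compound 1 gives 4330 nM. Compound 2 `C#CCN(CC)Cc1cn(-c2cc(NC(=S)NCC)ncn2)cn1` adds ethyl on that amine nitrogen. In this assay compound 2 reaches only the limit of the assay, > 50000 nM. Compound 3 `C#CCN(Cc1cn(-c2cc(NC(=S)NCC)ncn2)cn1)C(C)=O` bears acetyl on the same nitrogen instead. In this assay compound 3 likewise sits at the limit, > 50000 nM, so for compound 3 only a bound and no number is on record. The two steps from the secondary amine are an at least 11-fold higher number from compound 1 to compound 2 (1.06 log units; beyond the scatter) and an at least 11-fold higher number from compound 1 to compound 3 (1.06 log units; beyond the scatter); the step that the two limits leave unreadable from compound 2 to compound 3 cannot be read because the limit of > 50000 nM in this assay, at which 2 of the 3 values shown sit, holds both of its ends.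

Compound 4 `C#CCN(CC#C)Cc1cn(-c2cc(NC(=S)NCC)ncn2)cn1` follows from compound 3 by propargyl in place of acetyl on an amine nitrogen. The measured steps that bear on this change are the two that place a substituent on that nitrogen: both were large losses, and both end at the same limit, so the numbers do not say whether acetyl or an alkyl chain is the worse occupant. Compound 4 keeps the nitrogen fully substituted, so the estimated step of an at least 1.2-fold lower number from compound 3 to compound 4 (0.09 log units; that floor lies within the scatter) is small and a weak result is expected. Compound 4 is therefore estimated at 40000 nM, within a range from 8000 nM to 200000 nM, with a real chance that the assay again reports only its limit.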

Compound 4, half-maximal inhibitory concentration: > 50000 nM
Compound 4 gave a limit, no number; the forecaster's own chance of this, stated with the estimate: 60%; middle value at least 1.2-fold (0.09 log units) away from the limit.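

A second propargyl on the amine nitrogen gives an at least 11-fold higher number from compound 1 to compound 4 (1.06 log units; beyond the scatter), so the loss seen earlier with ethyl and acetyl also appears with this third substituent. Exchanging acetyl for propargyl does not bring back a measurable value: in this assay compound 4 gives only a limit, > 50000 nM, and among the compounds shown only the secondary amine, compound 1, has a number on record. The steps among compound 2, compound 3 and compound 4 cannot be read because all of them end at the same limit: the limit of > 50000 nM in this assay, at which 3 of the 4 values shown sit.

The compounds shown therefore give no order among ethyl, acetyl and propargyl on this nitrogen, and they do not show how far any of the three lies past the limit. Among these compounds, they also leave open whether a smaller group such as methyl on that nitrogen would keep a measurable value, and whether a longer chain in place of the single propargyl of compound 1 would do so.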